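Swapping a Sulfonyl for a Carbonyl on the Core Nitrogen

The source may report more compounds than this note shows. Statements on the series, on what has been measured and on what is new or still open speak of the compounds shown alone.

Going by the values given here, compound 1 `COc1cc(N(Cc2nc3ccccc3[nH]2)S(=O)(=O)c2ccc(F)cc2)cc(OC)c1OC` has the lowest number of the two measured so far in a functional assay on PC-3 cells (Homo sapiens) for inhibition, read by MTT assay, with a stated time of 48 h (on this read-out higher numbers stand for weaker inhibition and lower numbers for stronger inhibition), giving 7990 nM. Compound 2 `Cc1ccc(S(=O)(=O)N(Cc2nc3ccccc3[nH]2)c2ccc(Cl)cc2)cc1` gives 42200 nM in this assay, a gap beyond the scatter. Compound 3 `COc1cc(N(Cc2nc3ccccc3[nH]2)C(=O)c2ccc(C)cc2)cc(OC)c1OC` differs from compound 1 by one change: (4-methylphenyl)carbonyl in place of (4-fluorophenyl)sulfonyl on a nitrogen on an aromatic ring. Among the compounds with values here, no measured pair shows this change, so its effect is unknown; the expected step of a 1.3-fold higher number from compound 1 to compound 3 (0.10 log units; within the scatter) is small, within the scatter, and could fall in either direction. For compound 3 the estimated value is 10000 nM, with a range from 2500 nM to 40000 nM.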

Compound 3, half-maximal inhibitory concentration: 42000 nM
Estimate against measurement, compound 3: 4.2-fold (0.62 log units) below; the measured number lies above the stated range.
By their numbers in this assay, from the lowest: compound 1; then compounds 3 and 2 (each within the scatter of the next).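

On this nitrogen, the group matters: in this assay, (4-methylphenyl)carbonyl in place of (4-fluorophenyl)sulfonyl gives a 5.3-fold higher number from compound 1 to compound 3 (0.72 log units; beyond the scatter) and so weaker inhibition, which the earlier pair, differing in more than one place, could not show. The swap changes both the linking group and the group on the ring, so the step belongs to both changes together. Nothing measured here explains it.

Which of the two changes matters remains open; (4-fluorophenyl)carbonyl on this nitrogen would help separate them. How an amine at this position would behave is also unknown.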